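From furan-2-yl to pyridin-4-yl in a level series

This account rests on a few compounds, and the source may have more. Where it says the series, first, only, none or still open, it means among the compounds named here.

Three compounds share one core and differ only in a single aromatic group. In a functional assay on MDA-MB-231 cells (Homo sapiens) for cytotoxicity, read by ELISA, with a stated time of 2 days (on this read-out higher numbers stand for weaker inhibition and lower numbers for stronger inhibition), compound 1 (`Oc1cccc(-c2cc(-c3ccccc3)nc(-c3ccccc3)c2)c1`), which carries phenyl at that place, gives 19500 nM. Compound 2 (`Oc1cccc(-c2cc(-c3ccccc3)nc(-c3ccsc3)c2)c1`), with thiophen-3-yl, gives 19000 nM. Compound 3 (`Oc1cccc(-c2cc(-c3ccccc3)nc(-c3ccco3)c2)c1`), with furan-2-yl, gives 20800 nM. Compound 3 therefore stands level with the other two, as the measured steps show: a 1.1-fold higher number from compound 1 to compound 3 (0.03 log units; within the scatter) and a 1.1-fold higher number from compound 2 to compound 3 (0.04 log units; within the scatter).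

The next structure, compound 4 (`Oc1cccc(-c2cc(-c3ccccc3)nc(-c3ccncc3)c2)c1`), has pyridin-4-yl in place of furan-2-yl on an aromatic carbon, next to the ring nitrogen: pyridin-4-yl in place of furan-2-yl on an aromatic carbon.

The most relevant evidence is the set of swaps already measured at this same carbon. Besides the two above, there is a 1.0-fold lower number from compound 1 to compound 2 (0.01 log units; within the scatter). All three stay within the scatter, so the aromatic groups tried so far make no visible difference in this assay. None of those groups contains a ring nitrogen, however, so the data leave that feature untested, and the range should stay wide. No step beyond the scatter is expected, in either direction. The expected step is a 1.1-fold lower number from compound 3 to compound 4 (0.04 log units; within the scatter). For compound 4 the estimated value is 19000 nM, with an expected range from 9000 nM to 38000 nM.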

Compound 4, half-maximal inhibitory concentration: 12200 nM
Estimate against measurement, compound 4: 1.6-fold (0.19 log units) above; the measured number falls inside the stated range.
By their numbers in this assay, from the lowest: compounds 4, 2, 1 and 3 (each within the scatter of the next).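

Going by these compounds alone, the pyridin-4-yl group puts a nitrogen into the ring at this carbon for the first time, and in this assay it still gives no step beyond the scatter: a 1.7-fold lower number from compound 3 to compound 4 (0.23 log units; within the scatter), a 1.6-fold lower number from compound 2 to compound 4 (0.19 log units; within the scatter) and a 1.6-fold lower number from compound 1 to compound 4 (0.20 log units; within the scatter). These steps are larger than those among compounds 1, 2 and 3, but each remains within the scatter, so the data give no ground for calling compound 4 stronger than the others. This carbon has now carried a six-membered aromatic ring with a nitrogen, as well as phenyl, thiophen-3-yl and furan-2-yl, with all four compounds level, and no supporting evidence is available to explain this flat result.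

From the compounds shown here alone, all four groups at this carbon are aromatic rings, so it remains open whether an amine, a carboxylic acid or a longer chain there would produce a step beyond the scatter. Also open, going by these compounds, is whether pyridin-3-yl would behave like pyridin-4-yl, and whether changes to the 3-hydroxyphenyl group would matter more than those made at this carbon.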